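Morpholin-4-yl for thiomorpholin-4-yl: growth inhibition notes

A few compounds are considered here, and "the series" means these few. Any claim that something is new, unique, unknown or untested is made for them only; others in the source may bear on it.

Measured so far in a functional assay on HeLa cells (Homo sapiens) for cytotoxicity, read by MTT assay, with a stated time of 72 h, tested at 3 uM; a lower number here means less inhibition of growth, a higher number more inhibition of growth at the concentration tested:

compound 1, `Cc1ccnc(/C(N)=N/NC(=S)N2CCOCC2)c1`, gives 44.7%
compound 2, `Cc1ccnc(/C(N)=N/NC(=S)N2CCSCC2)c1`, gives 40.4%
compound 3, `N/C(=N\NC(=S)N1CCSCC1)c1ccc(F)cn1`, gives 62.9%

Compound 3 gives the highest number of the three in this assay; its gaps to compound 1 and to compound 2 are both beyond the usual scatter, so it is the most active of the measured set. Compound 1 and compound 2 lie within the scatter of each other, and the step of a number 4.3 percentage points higher from compound 2 to compound 1 (within the scatter) is small; the change behind it is morpholin-4-yl in place of thiomorpholin-4-yl on a thiocarbonyl carbon. How the core of compound 3 differs from the core of compound 2 is not broken down here.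

Compound 4, `N/C(=N\NC(=S)N1CCOCC1)c1ccc(F)cn1`, is not yet measured. For the measured compounds named here, it differs from compound 3 by morpholin-4-yl in place of thiomorpholin-4-yl on a thiocarbonyl carbon, which is the same change, at the same place, as the one made from compound 2 to compound 1. Because the earlier step of a number 4.3 percentage points higher from compound 2 to compound 1 (within the scatter) stayed within the scatter, a step of about the same size is expected for compound 4, namely a number 4.1 percentage points higher from compound 3 to compound 4 (within the scatter). This expectation rests on a single precedent and on the value of compound 3, 62.9%, from which the step is counted.

For compound 4 in this assay the estimate is 67%, with a range from 56% to 78%.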

Compound 4, percent growth inhibition at one concentration: 59.7%
For compound 4 the middle estimate is 7.3 percentage points above the measured one, and the stated range covers the measured number.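

In this assay, morpholin-4-yl in place of thiomorpholin-4-yl on a thiocarbonyl carbon gives a number 3.2 percentage points lower from compound 3 to compound 4 (within the scatter), and the two readings of this change agree within the scatter: the same change on two cores in this assay, a number 4.3 percentage points higher (within the scatter) from compound 2 to compound 1 and a number 3.2 percentage points lower (within the scatter) from compound 3 to compound 4, 7.5 percentage points apart, within the scatter of two such steps

On these two cores, then, the exchange carries over as a small step, and the pair with morpholin-4-yl and thiomorpholin-4-yl cannot be told apart in this read-out on either core. The data do not show a direction for the change, since the two steps point opposite ways and neither lies beyond the scatter, and two cores read at a single concentration do not show that the same would hold on a third core or in a full concentration series.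

Left open is whether a group of a different kind on the thiocarbonyl carbon, such as piperidin-1-yl, a piperazine ring carrying a free amine, or an open-chain dimethylamino group, would move the number beyond the scatter. Also open, from the compounds shown here alone, is how the series would respond to a chlorine atom or a methoxy group in place of the fluorine of compound 3 and compound 4.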